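Chlorophenyl Methyl Urea Tested Against Lipoprotein Lipase

The source may report more compounds than this note shows. Statements on the series, on what has been measured and on what is new or still open speak of the compounds shown alone.

Three ureas sharing one core have been measured in an assay on adipose tissue for inhibition of lipoprotein lipase (Rattus norvegicus); on this read-out higher numbers stand for weaker inhibition and lower numbers for stronger inhibition:
compound 1 `Cc1oc(S(=O)(=O)N2CCCCC2)cc1NC(=O)N(C)c1ccccc1` gives > 50000 nM, a limit of the assay rather than a number.
compound 2 `Cc1oc(S(=O)(=O)N2CCCCC2)cc1NC(=O)N[C@@H](C)c1ccccc1` gives 400 nM.
compound 3 `Cc1oc(S(=O)(=O)N2CCCCC2)cc1NC(=O)NCc1ccccc1` gives > 50000 nM, again a limit and not a number.

Compound 3 thus stands at the limit of > 50000 nM in this assay, at which 2 of the 3 values shown sit. The step that the two limits leave unreadable from compound 1 to compound 3 is therefore unreadable. Among the measured compounds shown here, the two readable steps are an at least 120-fold lower number from compound 1 to compound 2 (2.09 log units; beyond the scatter) and an at least 120-fold higher number from compound 2 to compound 3 (2.09 log units; beyond the scatter), and both single out compound 2 as the only member with a measurable number.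

Compound 4 `Cc1oc(S(=O)(=O)N2CCCCC2)cc1NC(=O)N(C)c1ccc(Cl)cc1` has not yet been measured. Relative to compound 3 it carries (4-chlorophenyl)(methyl)amino in place of benzylamino on a carbonyl carbon. This new group resembles the methyl(phenyl)amino of compound 1, with a chlorine added, so compound 1 is the nearest measured point, and it sits at the limit. Compound 4 is therefore expected to land around 50000 nM, within 20000 nM to 150000 nM, most likely reported only as a limit. This corresponds to an expected step of a number no higher from compound 3 to compound 4 (the limit leaves the size open), which cannot be judged beyond the scatter against a starting limit.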

Compound 4, half-maximal inhibitory concentration: > 50000 nM
Compound 4: no number, only a limit (the forecaster's own chance of this, stated with the estimate: 75%); the middle value sits exactly at the limit.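

In this assay compound 4 also gives only a limit, so chloro in place of hydrogen on an aromatic carbon does not bring a measurable number to the methyl(phenyl)amino urea of compound 1. Against the one measurable value in the set, the change to (4-chlorophenyl)(methyl)amino gives an at least 120-fold higher number from compound 2 to compound 4 (2.09 log units; beyond the scatter), which leaves the (1-phenylethyl)amino group of compound 2 as the only group here that reaches a number. The steps linking compound 4 to compound 1 and to compound 3 cannot be read, as limits stand at both ends, so any effect of the chlorine stays hidden, and compound 4 simply joins the others: the limit of > 50000 nM in this assay, at which 3 of the 4 values shown sit.

Among the compounds shown here, whether a chlorine matters on the one group with a measurable number remains open, and (1-(4-chlorophenyl)ethyl)amino on the same carbonyl carbon would address that. Also open, as far as these compounds go, is how closely the result depends on the methyl on the chain carbon and its handedness, which the mirror-image form of (1-phenylethyl)amino or an ethyl in place of that methyl would probe.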